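Aryl amide replacements on a shared core: compound 4

The compounds below may be only part of what the source reports. "The series", "measured", "known", "first", "only" and "open" are said of these compounds alone.

Measured so far in a functional assay on HEK293 cells for antagonist activity at metabotropic glutamate receptor 5 (Homo sapiens), read by FLIPR and calcium flux; a higher number here means a weaker inhibitor, a lower number a stronger inhibitor:
compound 1 `CN(C)c1ccc(C(=O)N[C@H]2CCC[C@H](NC(=O)c3cccc(Cl)c3)C2)cc1`: 473 nM
compound 2 `O=C(N[C@H]1CCC[C@H](NC(=O)c2cnccn2)C1)c1cccc(Cl)c1`: 1370 nM
compound 3 `O=C(Cc1ccccn1)N[C@H]1CCC[C@H](NC(=O)c2cccc(Cl)c2)C1`: only a limit of the assay, > 10000 nM

Compound 3 sits at the limit of > 10000 nM in this assay, at which 1 of the 3 values shown sits, and is the weakest of the three, its steps to both other compounds lying beyond the scatter. From compound 1 the step is an at least 21-fold higher number from compound 1 to compound 3 (1.32 log units; beyond the scatter); from compound 2 it is an at least 7.2-fold higher number from compound 2 to compound 3 (0.86 log units; beyond the scatter). Both steps set the (pyridin-2-yl)methyl amide well behind the amides whose aromatic ring sits directly on the carbonyl carbon, whether that ring is 4-(dimethylamino)phenyl or pyrazin-2-yl. The smaller step of a 2.9-fold higher number from compound 1 to compound 2 (0.46 log units; beyond the scatter) shows that exchanging one such directly attached ring for another costs far less.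

Compound 4 `O=C(N[C@H]1CCC[C@H](NC(=O)c2cccc(Cl)c2)C1)c1cccnc1` differs from compound 3 as follows: pyridin-3-yl in place of (pyridin-2-yl)methyl on a carbonyl carbon. Among the measured compounds shown here, the closest measured step is the one from compound 2 to compound 3, which the new compound in effect reverses: a six-membered heteroaryl ring again sits directly on the carbonyl carbon, as in compound 2. A lower number, beyond the scatter, is therefore expected, of the size seen between compound 2 and compound 3 or somewhat less. The estimate for compound 4 is 1500 nM, expected between 500 nM and 6000 nM, which amounts to an expected step of an at least 6.6-fold lower number from compound 3 to compound 4 (0.82 log units; beyond the scatter).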

Compound 4, half-maximal inhibitory concentration: 612 nM
Compound 4: the middle estimate sits 2.5-fold (0.39 log units) above what was measured; the range from low to high includes it.
By their numbers in this assay, from the lowest: compounds 1 and 4 (each within the scatter of the next); then compound 2. At a limit, above all of these: compound 3.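

In this assay, pyridin-3-yl in place of (pyridin-2-yl)methyl on the carbonyl carbon gives an at least 16-fold lower number from compound 3 to compound 4 (1.21 log units; beyond the scatter), which shows that a pyridine ring as such does not bring the loss seen with the (pyridin-2-yl)methyl amide. The figure for compound 3 is a limit of the assay and not a number, so this step has no upper end: the limit of > 10000 nM in this assay, at which 1 of the 4 values shown sits.

Among the directly attached rings, pyridin-3-yl cannot be told apart from 4-(dimethylamino)phenyl, a 1.3-fold higher number from compound 1 to compound 4 (0.11 log units; within the scatter), and it stands ahead of pyrazin-2-yl, a 2.2-fold lower number from compound 2 to compound 4 (0.35 log units; beyond the scatter), so the dimethylamino-substituted ring is not needed to reach this level at this position.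

The change between compound 3 and compound 4 alters both the carbon link to the carbonyl and the place of the ring nitrogen, and the compounds shown cannot separate these two changes. A pyridin-2-yl ring directly on the carbonyl carbon and a (pyridin-3-yl)methyl amide would pull them apart, while an unsubstituted phenyl ring on the same carbonyl carbon would show whether the ring nitrogen matters at all.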